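A few compounds are considered here, and "the series" means these few. Any claim that something is new, unique, unknown or untested is made for them only; others in the source may bear on it.

For the measured compounds named here, compound 1 `ClCC#CCSc1cnc2ccccc2c1Cl` gives the lowest number of the two compounds measured so far in a functional assay on SW707 cells (Homo sapiens) for antiproliferative activity, with a stated time of 72 h (on this read-out lower numbers stand for stronger inhibition and higher numbers for weaker inhibition), at 3.3 ug/mL. Going by the values given here, the only other measured compound, compound 2 `CSc1cnc2ccccc2c1SCC#CCOC(=O)/C=C/c1ccccc1`, gives 66.6 ug/mL in this assay, a number far enough from that of compound 1 to lie beyond the scatter. Compound 3 `OCC#CCSc1cnc2ccccc2c1Cl` has not yet been measured. It differs from compound 1 in one place: hydroxy in place of chloro on a saturated chain carbon bound to a triple-bonded carbon. Among the compounds with values here, no pair of measured compounds shows this exchange, so its effect cannot be read from any measured step; the two numbers at hand show only that compound 2, which differs from compound 1 in several places, inhibits more weakly. The step expected from this exchange is a 2.4-fold higher number from compound 1 to compound 3 (0.38 log units; beyond the scatter), toward weaker inhibition, though a step within the scatter remains plausible. The estimated value for compound 3 in this assay is 8 ug/mL, with a range from 3 ug/mL to 25 ug/mL.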

Compound 3, concentration for 50% inhibition: 6.2 ug/mL
For compound 3 the middle estimate is 1.3-fold (0.11 log units) above the measured one, within the range that was stated.
By their numbers in this assay, from the lowest: compounds 1 and 3 (each within the scatter of the next); then compound 2.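

The exchange of chloro for hydroxy on a saturated chain carbon bound to a triple-bonded carbon can now be read directly: in this assay it gives a 1.9-fold higher number from compound 1 to compound 3 (0.27 log units; within the scatter), so the two compounds cannot be told apart on this read-out. At this position, then, a chloro group with no hydrogen-bond donor and a hydroxy group with one are both compatible with numbers of this size, and the chloro is not needed to keep them there. Nothing at hand gives a reason for this outcome.

The compounds shown leave open whether an amine or a carboxylic acid at this position would also stay within the scatter of compound 1. They also leave open what a longer chain in place of the 4-hydroxybut-2-yn-1-yl group would do.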